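This account rests on a few compounds, and the source may have more. Where it says the series, first, only, none or still open, it means among the compounds named here.

Compound 3 `CNC(=O)N1CCCc2ccc(NC(=O)c3ccc(-c4cccnc4)cc3)cc21` holds the highest of the three measured numbers in a functional assay on MV4-11 cells (Homo sapiens) for antiproliferative activity, with a stated time of 6 days, tested at 1.56 uM; a lower number here means a weaker effect, a higher number a stronger effect of the compound at the concentration tested: compound 3 gives 62.5%. Compound 1 `CNC(=O)N1CCCc2ccc(NC(=O)c3ccc(-c4ccccc4)cc3)cc21` gives 19.7% and compound 2 `CNC(=O)N1CCCc2ccc(NC(=O)c3ccc(-c4ccn(S(C)(=O)=O)n4)cc3)cc21` gives 8.81%, so compound 3 stands clearly above both, as shown by a number 42.8 percentage points higher from compound 1 to compound 3 (beyond the scatter) and by a number 53.7 percentage points higher from compound 2 to compound 3 (beyond the scatter).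

Compound 4 `CNC(=O)N1CCCc2ccc(NC(=O)c3ccc(-c4cnn(S(C)(=O)=O)c4)cc3)cc21` differs from compound 3 in one place: 1-(methylsulfonyl)-1H-pyrazol-4-yl in place of pyridin-3-yl on an aromatic carbon. Among the measured compounds shown here, two measured steps bear on this change. The step of a number 10.9 percentage points lower from compound 1 to compound 2 (beyond the scatter) shows that a methylsulfonyl pyrazole in place of phenyl lowered the read-out modestly, while a number 53.7 percentage points higher from compound 2 to compound 3 (beyond the scatter) shows that pyridin-3-yl in place of such a pyrazole raised it by a large margin. For the measured compounds named here, in compound 4 the pyrazole enters as 1-(methylsulfonyl)-1H-pyrazol-4-yl rather than the 1-(methylsulfonyl)-1H-pyrazol-3-yl of compound 2, a variant no measured pair covers, so some uncertainty remains. Still, both measured steps point the same way, and a large fall is expected, a number 47.5 percentage points lower from compound 3 to compound 4 (beyond the scatter). Compound 4 is therefore estimated at 15%, with a likely range from 3% to 35%.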

Compound 4, a percentage reported as inhibition, at one concentration (the size of the read-out at that concentration, not a potency): 4.5%
Estimate against measurement, compound 4: 10.5 percentage points above; measured number inside the range.
By their numbers in this assay, from the lowest: compounds 4 and 2 (each within the scatter of the next); then compound 1; then compound 3.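

In this assay, the position para to a large group now shows that the low read-out does not depend on which of the two methylsulfonyl pyrazoles is attached: 1-(methylsulfonyl)-1H-pyrazol-4-yl in place of 1-(methylsulfonyl)-1H-pyrazol-3-yl gives a number 4.3 percentage points lower from compound 2 to compound 4 (within the scatter) and so separates the two isomers by no more than the usual scatter. Both pyrazoles also fall beyond the scatter against phenyl, and for the new isomer this appears as a number 15.2 percentage points lower from compound 1 to compound 4 (beyond the scatter) in a modest step that matches the one seen earlier for its isomer. The direct exchange of pyridin-3-yl for 1-(methylsulfonyl)-1H-pyrazol-4-yl gives a number 58 percentage points lower from compound 3 to compound 4 (beyond the scatter) and confirms that, among the four groups shown on this aromatic carbon, only pyridin-3-yl carries the read-out well clear of the others.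

The compounds shown leave open whether the ring nitrogen must sit as it does in pyridin-3-yl, which pyridin-2-yl, pyridin-4-yl or pyrimidin-5-yl would test, and whether an unsubstituted pyrazole without the methylsulfonyl group would behave like the two sulfonylated isomers. Nothing given here accounts for the differences between these groups.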